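Benzyl-type substituents on the ring amine of the shared core

A few compounds are considered here, and "the series" means these few. Any claim that something is new, unique, unknown or untested is made for them only; others in the source may bear on it.

Compound 3 `COc1ccc2nccc(C3CN(C4CCN(C)CC4)C(=O)O3)c2c1` carries only hydrogen on the saturated chain carbon bound to the amine nitrogen in the ring. In an in vitro functional assay on RBL cells for antagonist activity at C-C chemokine receptor type 8 (Homo sapiens), read by FLIPR and calcium flux (on this read-out higher numbers stand for weaker inhibition and lower numbers for stronger inhibition), compound 3 returns only a limit, < 50200 nM. Compound 1 `COc1ccc2nccc(C3CN(C4CCN(Cc5cc6ccccc6n5C)CC4)C(=O)O3)c2c1` gives 3160 nM in this assay, and compound 2 `COc1ccc2nccc(C3CN(C4CCN(Cc5ccc6ccccc6c5)CC4)C(=O)O3)c2c1` gives 1260 nM; the step of a 2.5-fold lower number from compound 1 to compound 2 (0.40 log units; beyond the scatter) is the only readable one, since a step that the limit leaves unreadable from compound 1 to compound 3 and a step that the limit leaves unreadable from compound 2 to compound 3 are cut off by the limit of < 50200 nM in this assay, at which 1 of the 3 values shown sits. Compound 4 `COc1ccc2nccc(C3CN(C4CCN(Cc5ccccc5Cl)CC4)C(=O)O3)c2c1` carries the change (2-chlorophenyl in place of hydrogen on a saturated chain carbon bound to an amine nitrogen in a ring). A 2-chlorophenyl is neither of the two aryl groups measured so far, so compound 4 is expected to land between the limit and the two readable values, a step that the limit leaves unreadable from compound 3 to compound 4. The estimate for compound 4 is 6000 nM, between 1500 nM and 25000 nM.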

Compound 4, half-maximal inhibitory concentration: < 50200 nM
Compound 4: only a limit was reported; the forecaster's own chance of this, stated with the estimate: 20%; the middle value does not contradict the limit.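

Compound 4 gives only a limit, so no step from compound 1, compound 2 or compound 3 to compound 4 can be read: the limit of < 50200 nM in this assay, at which 2 of the 4 values shown sit.

The compounds shown leave open how the 2-chlorophenyl of compound 4 compares with the hydrogen of compound 3.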